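The source may hold more compounds than are shown below. What is called first, only, known or untested is meant among the compounds shown, and "the series" means these compounds.

Measured so far in an assay for binding affinity to leukotriene B4 receptor 1 (Homo sapiens); on this read-out higher numbers stand for weaker inhibition and lower numbers for stronger inhibition: compound 1 `COc1ccc(CCCCCCCCOc2ccc(C[S+]([O-])c3ccccc3)nc2/C=C/C(=O)O)cc1` gives 37 nM; compound 2 `COc1ccc(CCCCCCCCOc2ccc(C[S+]([O-])c3cccc(NS(=O)(=O)c4ccccc4)c3)nc2/C=C/C(=O)O)cc1` gives 147 nM; compound 3 `COc1ccc(CCCCCCOc2ccc(CC(O)c3cccc(C(=O)O)c3)nc2/C=C/C(=O)O)cc1` gives 165 nM.

Compound 1 stands lowest of the three numbers in this assay, the other two lying beyond the scatter above it. Compound 4 `COc1ccc(CCCCCCCCOc2ccc(CSc3cccc(C(=O)O)c3)nc2/C=C/C(=O)O)cc1` differs from compound 1 in one place: a group of 10 heavy atoms (7 carbon, 2 oxygen, 1 sulfur; one six-membered aromatic ring of carbon only) in place of a group of 8 heavy atoms (6 carbon, 1 oxygen, 1 sulfur; one six-membered aromatic ring of carbon only), on a saturated chain carbon bound to an aromatic carbon. Within the data shown here, no measured step covers this exact change. Among the measured compounds shown here, the only single-point step, a 4.0-fold higher number from compound 1 to compound 2 (0.60 log units; beyond the scatter), shows that enlarging the pendant ring of compound 1 cost affinity. Compound 3, which also carries a carboxyl on its pendant ring but differs in more than one place, gives only its value for comparison. A weakening step of similar size is therefore expected for compound 4, a 3.0-fold higher number from compound 1 to compound 4 (0.47 log units; beyond the scatter), giving an estimate of 110 nM with a range of 35 nM to 350 nM.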

Compound 4, inhibition constant: 80 nM
The estimate for compound 4 lay 1.4-fold (0.14 log units) above the measured number, within the range that was stated.
By their numbers in this assay, from the lowest: compound 1; then compounds 4, 2 and 3 (each within the scatter of the next, the first and the last beyond it).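

In this assay, the position on a saturated chain carbon bound to an aromatic carbon accepts (3-carboxyphenyl)sulfanyl at a modest cost, a 2.2-fold higher number from compound 1 to compound 4 (0.33 log units; beyond the scatter). A carboxyl-bearing ring at this position therefore retains measurable affinity, though the number stays beyond the scatter above that of compound 1. No available evidence accounts for this step.

The whole group changes in this step, so the shares of the carboxyl and of the lost oxygen remain unseparated. Going by these compounds, whether an amine or a tetrazole on that ring would behave similarly remains open.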